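A few compounds are considered here, and "the series" means these few. Any claim that something is new, unique, unknown or untested is made for them only; others in the source may bear on it.

Three compounds sharing one core have been examined in a physicochemical assay for lipophilicity, in phosphate buffer, measured as octanol-water partition; a higher number here means a more lipophilic compound, a lower number a more polar compound. Compound 1 `O=C(NC(=S)Nc1ccccc1Cl)Nc1ccc2c(c1)C(=O)C(=O)N2Cc1ccccc1` gives 3.01, compound 2 `Cc1ccccc1NC(=S)NC(=O)Nc1ccc2c(c1)C(=O)C(=O)N2Cc1ccccc1` gives 2.98, and compound 3 `Cc1ccc(NC(=S)NC(=O)Nc2ccc3c(c2)C(=O)C(=O)N3Cc2ccccc2)cc1` gives 2.96. Compound 3 holds the lowest of the three numbers, yet its gaps to both neighbours fall within the scatter: the step from compound 2 to compound 3 is a number 0.02 log units lower from compound 2 to compound 3 (within the scatter) and the step from compound 1 to compound 3 is a number 0.05 log units lower from compound 1 to compound 3 (within the scatter). Compound 4 `COc1ccccc1NC(=S)NC(=O)Nc1ccc2c(c1)C(=O)C(=O)N2Cc1ccccc1` differs from compound 3 in one place: 2-methoxyphenyl in place of 4-methylphenyl on an amide-type nitrogen. For the measured compounds named here, the steps that bear on this, the swap of chloro for methyl a number 0.03 log units lower from compound 1 to compound 2 (within the scatter) and the two swaps of the whole aryl group already named, all stayed within the scatter. Going by the values given here, no measured step, however, introduces an oxygen-bearing substituent, so those steps cannot be read directly onto compound 4. On the strength of the clustered values of compounds 1, 2 and 3, the number for compound 4 in this assay is expected to sit somewhat lower, an estimated step of a number 0.36 log units lower from compound 3 to compound 4 (beyond the scatter), giving an expected value for compound 4 of 2.6, within a range from 2.2 to 3.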

Compound 4, partition coefficient: 2.38
For compound 4 the middle estimate is 0.22 log units above the measured one; the measured number falls inside the stated range.
By their numbers in this assay, from the lowest: compound 4; then compounds 3, 2 and 1 (each within the scatter of the next).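

In this assay the aryl group on the amide-type nitrogen now shows a change that reaches beyond the scatter: 2-methoxyphenyl in place of 4-methylphenyl gives a number 0.58 log units lower from compound 3 to compound 4 (beyond the scatter) on this nitrogen, whose other neighbour is the thiocarbonyl carbon. The swap on the aromatic carbon reads the same way, with methoxy in place of methyl giving a number 0.60 log units lower from compound 2 to compound 4 (beyond the scatter) and methoxy in place of chloro giving a number 0.63 log units lower from compound 1 to compound 4 (beyond the scatter), while the earlier swaps among the chloro, methyl and 4-methylphenyl compounds all stayed within the scatter. The compounds shown leave open whether 4-methoxyphenyl on the same nitrogen would give a step of this size, as methoxy appears here only within 2-methoxyphenyl. Also open, on these data alone, is how a hydroxyl, an amine or a longer ethoxy chain on that aromatic carbon would read in this assay, and no measurement at hand accounts for the size of these steps.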